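Swapping the Benzyl on Sulfur for a Cyclohexyl

The source may report more compounds than this note shows. Statements on the series, on what has been measured and on what is new or still open speak of the compounds shown alone.

Of the compounds shown here, two built on one shared core have been measured. Compound 1 `Cn1c(=O)c2c(nc(SCc3ccccc3)n2C)n(C)c1=O` gives 8220 nM in an assay on isolated protein for inhibition of Amine oxidase [flavin-containing] A (Homo sapiens), read by fluorescence (on this read-out lower numbers stand for stronger inhibition and higher numbers for weaker inhibition), the higher of the two numbers recorded, so it is the weaker inhibitor of the pair. Among the measured compounds shown here, compound 2 `Cn1c(=O)c2c(nc(SCc3ccc(Cl)cc3)n2C)n(C)c1=O` gives 2770 nM in this assay; the one comparison available is a 3.0-fold lower number from compound 1 to compound 2 (0.47 log units; beyond the scatter), a chloro in place of hydrogen on an aromatic carbon.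

Compound 3 `Cn1c(=O)c2c(nc(SC3CCCCC3)n2C)n(C)c1=O` has not yet been measured. It differs from compound 1 in one place: cyclohexyl in place of benzyl on a sulfur.

For the measured compounds named here, no measured step covers this kind of change. The step from compound 1 to compound 2 alters one carbon of the aromatic ring and leaves the ring itself in place, whereas compound 3 replaces that ring with a non-aromatic one. Because a 3.0-fold lower number from compound 1 to compound 2 (0.47 log units; beyond the scatter) shows that this ring is a part where changes register, its removal is expected to cost rather than help, with wide uncertainty. Compound 3 is therefore expected to give about 13000 nM in this assay, plausibly between 4000 nM and 45000 nM. This estimate corresponds to an expected 1.6-fold higher number from compound 1 to compound 3 (0.20 log units; within the scatter).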

Compound 3, half-maximal inhibitory concentration: 24400 nM
Beside the measured number, compound 3's estimate is 1.9-fold (0.27 log units) below it, within the range that was stated.
By their numbers in this assay, from the lowest: compound 2; then compound 1; then compound 3.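

In this assay, the change from benzyl to cyclohexyl on a sulfur gives a 3.0-fold higher number from compound 1 to compound 3 (0.47 log units; beyond the scatter), so this position responds not only to a substituent on the ring, as in a 3.0-fold lower number from compound 1 to compound 2 (0.47 log units; beyond the scatter), but also to the nature of the ring itself. The two steps from compound 1 run in opposite directions: adding the chloro lowers the number, while replacing benzyl with cyclohexyl raises it. Nothing available here explains why the number rises.

The change also does more than one thing at once: a six-membered aromatic ring gives way to a six-membered non-aromatic ring, and the group goes from 7 heavy atoms to 6, so the compounds shown cannot separate the effect of losing aromaticity from that of altering the group's size and shape. A phenyl group placed directly on the sulfur or a longer chain such as phenylethyl would help pull these apart, and a group carrying an amine would show how this position responds to something other than a ring of carbon only.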